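Hydrazone aryl swaps on a shared core

This account rests on a few compounds, and the source may have more. Where it says the series, first, only, none or still open, it means among the compounds named here.

Compound 1 `Cn1c(=O)c(=O)n(C2CCCC2)c2nc(N/N=C/c3ccc(C(F)(F)F)cc3)ncc21` gives 23600 nM in a functional assay on PC-3 cells (Homo sapiens) for antiproliferative activity, read by MTT assay; on this read-out higher numbers stand for weaker inhibition and lower numbers for stronger inhibition. Compound 2 `Cc1cc(C)c(/C=N/Nc2ncc3c(n2)n(C2CCCC2)c(=O)c(=O)n3C)c(C)c1` gives 13900 nM in this assay, the lower of the two numbers, though the step of a 1.7-fold lower number from compound 1 to compound 2 (0.23 log units; within the scatter) lies within the scatter. Compound 3 `COc1ccc(/C=N/Nc2ncc3c(n2)n(C2CCCC2)c(=O)c(=O)n3C)c(OC)c1` carries 2,4-dimethoxyphenyl in place of 2,4,6-trimethylphenyl on a carbon with a double bond to nitrogen. Within the data shown here, only the step from compound 1 to compound 2 bears on this aryl change, and it was small, so no step beyond the scatter is expected in this assay. For compound 3 the expected step is a 1.1-fold higher number from compound 2 to compound 3 (0.03 log units; within the scatter), with an estimate of 15000 nM, between 5000 nM and 45000 nM.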

Compound 3, half-maximal inhibitory concentration: > 100000 nM
Compound 3: only a limit was reported (the forecaster's own chance of this, stated with the estimate: 10%); middle value at least 6.6-fold (0.82 log units) away from the limit.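

The aryl group on a carbon with a double bond to nitrogen turns out not to be indifferent in this assay, although the earlier swap stayed within the scatter. With 2,4-dimethoxyphenyl the read-out shows an at least 7.1-fold higher number from compound 2 to compound 3 (0.85 log units; beyond the scatter) and an at least 4.2-fold higher number from compound 1 to compound 3 (0.62 log units; beyond the scatter). Compound 3 gives only a limit, so both steps are minimum sizes: the limit of > 100000 nM in this assay, at which 1 of the 3 values shown sits.

From the compounds shown here alone, it remains open whether the change follows both methoxy groups or just one of them. Also open, going by these compounds, is how an aryl group bearing an amine or a carboxylic acid would read here.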